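The source may report more compounds than this note shows. Statements on the series, on what has been measured and on what is new or still open speak of the compounds shown alone.

Three pyrazole-linked enone compounds have been measured in a functional assay on SW-620 cells (Homo sapiens) for cytotoxicity, read by sulforhodamine B assay, with a stated time of 48 h, tested at 1 uM; a higher number here means a weaker effect of the compound at the concentration tested, a lower number a stronger effect. Compound 1 `COc1ccc(-c2cc(/C=C/C(=O)c3ccc(OC)c(OC)c3)[nH]n2)cc1` gives 65%, compound 2 `COc1cc(-c2cc(/C=C/C(=O)c3ccc(Cl)c(Cl)c3)[nH]n2)cc(OC)c1OC` gives 91%, and compound 3 `COc1cc(C(=O)/C=C/c2cc(-c3cc(OC)c(OC)c(OC)c3)n[nH]2)cc(OC)c1OC` gives 85%. Compound 2 therefore shows the highest number of the three: its nearest neighbour is compound 3, whose number is lower by an amount within the scatter, while compound 1 lies lower by an amount beyond the scatter. Compound 4 `COc1cc(-c2cc(/C=C/C(=O)c3ccc(F)c(F)c3)[nH]n2)cc(OC)c1OC` has not yet been measured in this assay. It differs from compound 2 by 3,4-difluorophenyl in place of 3,4-dichlorophenyl on a carbonyl carbon. Among the measured compounds shown here, no step between measured compounds separates these two groups, so the expected step of a number 1 percentage points lower from compound 2 to compound 4 (within the scatter) is small, if any, and not beyond the scatter. Compound 4 is expected to give 90%, in the range 76% to 100%.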

Compound 4, a percentage reported as activity, at one concentration (the size of the read-out at that concentration, not a potency): 93%
Estimate against measurement, compound 4: 3 percentage points below, and the stated range covers the measured number.
By their numbers in this assay, from the lowest: compound 1; then compounds 3, 2 and 4 (each within the scatter of the next).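

In this assay, among the compounds shown here, the step of a number 2 percentage points higher from compound 2 to compound 4 (within the scatter) is the first that can be read at this place, on a carbonyl carbon. It shows that 3,4-difluorophenyl can stand in place of 3,4-dichlorophenyl without a difference beyond the scatter, so this exchange of halogens does not separate the two compounds at the concentration tested. Going by these compounds, whether an aminophenyl or a carboxyphenyl group on this carbonyl carbon would move the number stays open, as does whether the same exchange would give the same result with the other groups of compound 1. Nothing given here offers an explanation for this result.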